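Pyridin-4-yl replacing 3-hydroxy-4-methoxyphenyl on the shared core

The source may hold more compounds than are shown below. What is called first, only, known or untested is meant among the compounds shown, and "the series" means these compounds.

Compound 1 `COc1cc(-n2c(-c3ccncc3)cccc2=O)cc(OC)c1OC` gives 1780 nM
Compound 2 `COc1ccc(-n2c(-c3cc(OC)c(OC)c(OC)c3)cccc2=O)cc1O` gives 1220 nM

In a functional assay on HepG2 cells (Homo sapiens) for cytotoxicity, read by spectrophotometry, with a stated time of 72 h (on this read-out higher numbers stand for weaker inhibition and lower numbers for stronger inhibition), these two values lie within the scatter of each other, so compound 2 stands level with compound 1 and neither stands apart.

Compound 3 `COc1cc(-c2cccc(=O)n2-c2ccncc2)cc(OC)c1OC` has not yet been measured. Its difference from compound 2 is pyridin-4-yl in place of 3-hydroxy-4-methoxyphenyl on an aromatic nitrogen. Among the compounds with values here, no measured pair shows this change alone, so the expectation rests on little. Compound 1 also carries pyridin-4-yl, though not on an aromatic nitrogen, and gives 1780 nM in this assay, which argues against a very large loss. A modest estimated step of a 2.3-fold higher number from compound 2 to compound 3 (0.36 log units; beyond the scatter) is expected, toward a higher number and so weaker inhibition. Compound 3 is estimated at 2800 nM with an expected range of 800 nM to 10000 nM in this measurement.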

Compound 3, half-maximal inhibitory concentration: 2520 nM
For compound 3 the middle estimate is 1.1-fold (0.05 log units) above the measured one, and the stated range covers the measured number.
By their numbers in this assay, from the lowest: compounds 2, 1 and 3 (each within the scatter of the next, the first and the last beyond it).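

In this assay, the place on the aromatic nitrogen of the shared core now has a step of its own: pyridin-4-yl in place of 3-hydroxy-4-methoxyphenyl gives a 2.1-fold higher number from compound 2 to compound 3 (0.32 log units; beyond the scatter), which is modest but beyond the scatter. The earlier compounds shown here offered no change in this one place, and this step shows that the exchange moves the number toward weaker inhibition without removing it. Within the data shown here, the exchange alters the ring, the count of heavy atoms and the hydrogen-bond donor together, so the single step cannot tell which of these matters, and nothing measured on these compounds gives a reason for it.

Open, as far as these compounds go, is how a phenyl ring carrying only hydroxy or only methoxy would read at this place. Also open, from the compounds shown here alone, is whether an amine or a carboxylic acid on that ring would shift the number further.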